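Swapping the sulfonamide ring on a chromone-derived cytotoxic series

The source may report more compounds than this note shows. Statements on the series, on what has been measured and on what is new or still open speak of the compounds shown alone.

Measured compounds:
Compound 1 `O=C1/C(=C/c2coc3ccccc3c2=O)N=C(c2ccc(Cl)cc2)N1c1ccc(S(=O)(=O)Nc2ncccn2)cc1`: > 100000 nM
Compound 2 `Cc1cc(NS(=O)(=O)c2ccc(N3C(=O)/C(=C/c4coc5ccccc5c4=O)N=C3c3ccc(Cl)cc3)cc2)no1`: > 100000 nM
Compound 3 `CCOC1Oc2ccccc2C(=O)/C1=C/Nc1ccc(S(=O)(=O)Nc2cc(C)on2)cc1`: 25800 nM

In a functional assay on MCF7 cells (Homo sapiens) for cytotoxicity, read by sulforhodamine B assay, with a stated time of 72 h (a higher number here means a weaker inhibitor, a lower number a stronger inhibitor), compound 1 gives > 100000 nM, which is a limit of the assay rather than a number. Compound 2 likewise gives > 100000 nM, also a limit. Compound 3, built on a different core, gives 25800 nM; the difference between the two cores is not broken down here. The change from compound 2 to compound 1 is pyrimidin-2-yl in place of 5-methyl-1,2-oxazol-3-yl on a sulfonamide nitrogen, and the step it made, a step that the two limits leave unreadable from compound 2 to compound 1, cannot be read because both values are limits (the limit of > 100000 nM in this assay, at which 2 of the 3 values shown sit). Compound 4 `CCOC1Oc2ccccc2C(=O)/C1=C/Nc1ccc(S(=O)(=O)Nc2ncccn2)cc1` carries the same change, (pyrimidin-2-yl in place of 5-methyl-1,2-oxazol-3-yl on a sulfonamide nitrogen), on the core of compound 3. Among the measured compounds shown here, since the only measured example of this change gives no readable size, the step from compound 3 to compound 4 is expected to be small, a 1.2-fold higher number from compound 3 to compound 4 (0.07 log units; within the scatter). Compound 4 is therefore estimated at 30000 nM, somewhere between 8000 nM and 100000 nM.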

Compound 4, half-maximal inhibitory concentration: 30100 nM
For compound 4 the middle estimate is 1.0-fold (0.00 log units) below the measured one; measured number inside the range.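

Putting pyrimidin-2-yl in place of 5-methyl-1,2-oxazol-3-yl on the sulfonamide nitrogen makes a 1.2-fold higher number from compound 3 to compound 4 (0.07 log units; within the scatter) in this assay, so the two rings cannot be told apart on this core. Among the compounds shown here, this is the only readable example of the change, and it shows no measurable effect on one core only. On the other core the step cannot be read, so the data cannot show whether the result carries from one core to the other, as compound 1 and compound 2 both give a limit rather than a number: the limit of > 100000 nM in this assay, at which 2 of the 4 values shown sit.

Going by these compounds, only these two rings appear on the sulfonamide nitrogen, so the effect of a plain phenyl ring or an acetyl group there remains open. Also open, on these data alone, is whether any change at this nitrogen could give a step beyond the scatter.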